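This account rests on a few compounds, and the source may have more. Where it says the series, first, only, none or still open, it means among the compounds named here.

In a physicochemical assay for lipophilicity, read by HPLC, at pH 7.5 (a lower number here means a more polar compound, a higher number a more lipophilic compound), compound 1 `CC[C@@H](Nc1c(C#N)c(-c2ccc(-c3ccccc3F)cc2)nc2cnccc12)C(N)=O` gives 2.7, the highest of the three numbers in hand. Compound 3 `CCOc1ccccc1-c1ccc(-c2nc3cnccc3c(C[C@H](C)C(=O)O)c2C#N)cc1` stands nearest and gives 2.2, a gap beyond the scatter; compound 2 `N#Cc1c(-c2ccc(Br)cc2)nc2cnccc2c1NCC(N)=O` stands furthest and gives 1.9, also beyond the scatter. No pair among these three differs in one place only, so no single-point step can be read from the measured set. Compound 4 `CC[C@@H](Nc1c(C#N)c(-c2ccc(-c3ccccc3Cl)cc2)nc2cnccc12)C(N)=O` is next for this assay and differs from compound 1 in one place: chloro in place of fluoro on an aromatic carbon. The step of a number 0.50 log units higher from compound 1 to compound 4 (beyond the scatter) is expected to run upward and beyond the scatter, starting from compound 1 at 2.7. Compound 4 is accordingly estimated at 3.2, within a range from 2.8 to 3.6.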

Compound 4, distribution coefficient: 2.9
For compound 4 the middle estimate is 0.30 log units above the measured one, within the range that was stated.
By their numbers in this assay, from the lowest: compounds 2 and 3 (each within the scatter of the next); then compounds 1 and 4 (each within the scatter of the next).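

Among these compounds, at the place ortho to a large group, 2-fluorophenyl to 2-chlorophenyl gives the only single-place step in hand: in this assay, a number 0.20 log units higher from compound 1 to compound 4 (within the scatter). On the core of compound 1, this read-out therefore does not separate chloro from fluoro at this position. No measured finding bears on this step.

From the compounds shown here alone, whether an amine or a carboxylic acid on this aromatic carbon would give a step beyond the scatter remains open. Also open, going by these compounds, is whether chloro in place of fluoro reads the same on other cores.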